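Mirror-image partner of compound 2: expected cytotoxicity

The source may report more compounds than this note shows. Statements on the series, on what has been measured and on what is new or still open speak of the compounds shown alone.

Of the compounds shown here, two have numbers so far. Compound 1 `COc1cc([C@@H]2C[C@@]2(CO)C(=O)Nc2ccccc2Cl)cc(OC)c1OC` gives 10700 nM in a functional assay on SW480 cells (Homo sapiens) for cytotoxicity, read by MTT assay, with a stated time of 48 h; a lower number here means a stronger inhibitor, a higher number a weaker inhibitor. Compound 2 `COc1cc([C@H]2C[C@]2(CO)C(=O)NCc2ccc(C)cc2)cc(OC)c1OC` gives 94000 nM in this assay and so stands as the weaker of the two measured compounds, its number being higher than that of compound 1 by a gap beyond the scatter. Since compound 1 and compound 2 differ in more than one place, their two values alone say nothing about any single change.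

Compound 3 `COc1cc([C@@H]2C[C@@]2(CO)C(=O)NCc2ccc(C)cc2)cc(OC)c1OC` is not yet measured. It is the mirror image of compound 2: the two compounds have the same atoms and bonds and differ only in configuration as drawn: 2 of 2 stereo elements differ (all stereocentres are inverted: mirror images); a stereocentre at a saturated ring carbon is drawn R in compound 2 and S in compound 3; a stereocentre at a saturated ring carbon is drawn S in compound 2 and R in compound 3. For the measured compounds named here, no step between two measured compounds of this kind exists in the set, so the size of the step is open. A moderate step in either direction is possible, and a change within the scatter is equally plausible. The expected step from compound 2 to compound 3 in this assay is a 1.9-fold lower number from compound 2 to compound 3 (0.27 log units; within the scatter). Compound 3 is expected to give 50000 nM in this assay, in the range 10000 nM to 150000 nM.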

Compound 3, half-maximal inhibitory concentration: 76300 nM
Beside the measured number, compound 3's estimate is 1.5-fold (0.18 log units) below it, within the range that was stated.
By their numbers in this assay, from the lowest: compound 1; then compounds 3 and 2 (each within the scatter of the next).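

In this assay, for the compounds shown here, inverting both stereocentres gives a 1.2-fold lower number from compound 2 to compound 3 (0.09 log units; within the scatter), the first configuration-only comparison, and it does not separate the two mirror images. The comparison can be read as one of stereochemistry alone, with no second change to account for: the fact that compounds 2 and 3 differ only in the configuration as drawn. With configuration unchanged, 4-methylbenzyl in place of 2-chlorophenyl on an amide-type nitrogen gives a 7.1-fold higher number from compound 1 to compound 3 (0.85 log units; beyond the scatter), so among these pairs the larger step comes with the change on that nitrogen and not with the inversion.

From the compounds shown here alone, whether the same lack of separation between mirror images holds with 2-chlorophenyl on the amide-type nitrogen remains open, as the pair read here carries 4-methylbenzyl only. Also open, going by these compounds, is how that larger step divides among its parts: an unsubstituted benzyl or a plain phenyl on the same nitrogen would show whether it follows the methyl, the chlorine or the change from a phenyl to a benzyl group.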